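The source may hold more compounds than are shown below. What is called first, only, known or untested is meant among the compounds shown, and "the series" means these compounds.

Measured in a functional assay on DLD-1 cells (Homo sapiens) for cytotoxicity, with a stated time of 48 h; on this read-out lower numbers stand for stronger inhibition and higher numbers for weaker inhibition:
- compound 1 `C[S+]([O-])/C=C/c1cc(=O)c2ccccc2o1`: 8000 nM
- compound 2 `Cc1cccc2oc(/C=C/[S+](C)[O-])cc(=O)c12`: 5500 nM

Going by the values given here, only two numbers are available, and compound 1 cannot be told apart from the other one: a 1.5-fold lower number from compound 1 to compound 2 (0.16 log units; within the scatter). Compound 3 `CCCCC(=O)Oc1ccc2oc(/C=C/[S+](C)[O-])cc(=O)c2c1` has not yet been measured in this assay. It differs from compound 1 as follows: (butylcarbonyl)oxy in place of hydrogen on an aromatic carbon. In words, this is (butylcarbonyl)oxy in place of hydrogen on an aromatic carbon.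

Among the compounds with values here, the only measured step that bears on this is methyl in place of hydrogen on an aromatic carbon, seen in compound 2 (a 1.5-fold lower number from compound 1 to compound 2 (0.16 log units; within the scatter)). Within the data shown here, that is a much smaller group, and no measured compound carries anything like the new one, so the guidance is weak. No step beyond the scatter is expected, though with a wide margin either way. The expected step is a 1.3-fold lower number from compound 1 to compound 3 (0.12 log units; within the scatter). For compound 3 the estimated value is 6000 nM, with an expected range of 2000 nM to 18000 nM.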

Compound 3, half-maximal inhibitory concentration: 6700 nM
Estimate against measurement, compound 3: 1.1-fold (0.05 log units) below; low and high end bracket the measured number.
By their numbers in this assay, from the lowest: compounds 2, 3 and 1 (each within the scatter of the next).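

In this assay, (butylcarbonyl)oxy on an aromatic carbon, meta to a fused ring and para to a fused ring, gives a 1.2-fold lower number from compound 1 to compound 3 (0.08 log units; within the scatter). This position on the core of compound 1 therefore accepts a substituent of 7 heavy atoms with no step beyond the scatter, something the much smaller methyl of compound 2 could not show. Nothing available speaks to the cause of this result.

The compounds shown do not tell whether a carboxylic acid, an amine or a longer chain on this same aromatic carbon would give a step beyond the scatter. They also leave open whether (butylcarbonyl)oxy would give a similar number on another aromatic carbon of the core.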